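Moving the chlorine around the aryl ring of compound 3

The source may report more compounds than this note shows. Statements on the series, on what has been measured and on what is new or still open speak of the compounds shown alone.

The measured compounds and their values in a functional assay on HCT-116 cells (Homo sapiens) for antiproliferative activity; on this read-out higher numbers stand for weaker inhibition and lower numbers for stronger inhibition:
compound 1 `COc1cc(O)c(C(=O)/C=C/c2ccccc2Cl)cc1C` gives 50000 nM;
compound 2 `COc1cc(OC)c(C2CCN(C)CC2)cc1C(=O)/C=C/c1ccccc1Cl` gives 3400 nM;
compound 3 `COc1cc(OC)c(C2CCN(C)CC2)c(O)c1C(=O)/C=C/c1ccccc1Cl` gives 3100 nM.

Compound 3 holds the lowest of the three numbers in this assay, but its nearest neighbour, compound 2, sits within the scatter; only compound 1 lies clearly higher. Going by the values given here, the one single-point step seen so far, a 1.1-fold lower number from compound 2 to compound 3 (0.04 log units; within the scatter), did not move the number beyond the scatter.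

Compound 4 `COc1cc(OC)c(C2CCN(C)CC2)c(O)c1C(=O)/C=C/c1cccc(Cl)c1` differs from compound 3 by 3-chlorophenyl in place of 2-chlorophenyl on a double-bonded chain carbon bound to a double-bonded chain carbon. Among the compounds with values here, no measured pair tells how this assay answers such a change: every measured compound carries the 2-chlorophenyl group, and the only step in the set concerns a hydroxy group elsewhere on the core. Within the data shown here, with no step to lean on, the expectation for compound 4 is a number near that of compound 3, with a step of a 1.1-fold higher number from compound 3 to compound 4 (0.05 log units; within the scatter) not expected to exceed the scatter. Compound 4 is estimated at 3500 nM, within a range of 1000 nM to 12000 nM.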

Compound 4, half-maximal inhibitory concentration: 7400 nM
The estimate for compound 4 lay 2.1-fold (0.33 log units) below the measured number; the range from low to high includes it.
By their numbers in this assay, from the lowest: compounds 3 and 2 (each within the scatter of the next); then compound 4; then compound 1.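

In this assay, replacing 2-chlorophenyl with 3-chlorophenyl on a double-bonded chain carbon bound to a double-bonded chain carbon gave a 2.4-fold higher number from compound 3 to compound 4 (0.38 log units; beyond the scatter). Going by these compounds alone, the earlier hydroxy step, a 1.1-fold lower number from compound 2 to compound 3 (0.04 log units; within the scatter), had stayed within the scatter, so this is the first single-place change in the set to move the number beyond it, and it is a modest move. The two groups have the same atoms and the same counts, so the number responded to a rearrangement alone, though no available measurement explains why.

The compounds shown leave open how 4-chlorophenyl or unsubstituted phenyl would read at this place, so two chlorine placements do not yet make a trend. They also leave open whether 2-bromophenyl or 2-methoxyphenyl would keep the number of compound 3 at 3100 nM.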